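This account rests on a few compounds, and the source may have more. Where it says the series, first, only, none or still open, it means among the compounds named here.

Of the compounds shown here, two built on a shared core have been measured in a functional assay on HEK293 cells for agonist activity at G-protein coupled receptor 39 (Homo sapiens), read by scintillation proximity assay and inositol phosphate accumulation, with a stated time of 75 min; on this read-out lower numbers stand for an effect already at smaller amounts and higher numbers for an effect only at larger amounts of compound. Compound 1 `Cc1nn(-c2ncnc3nc[nH]c23)c2c1C(c1ccc(F)cc1Cl)CC(=O)N2` gives 280 nM in this assay, and compound 2 `Cc1nn(-c2ncnc3nc[nH]c23)c2c1C(C(=O)NCc1ccc(F)cc1)CC(=O)N2` gives 1220 nM in the same assay. Compound 1 therefore stands at the lowest of the two numbers, and compound 2 lies well beyond the usual scatter from it. Compound 3 `Cc1nn(-c2ncnc3nc[nH]c23)c2c1C(OCc1ccccc1F)CC(=O)N2` has not yet been measured. It differs from compound 1 in one place: (2-fluorobenzyl)oxy in place of 2-chloro-4-fluorophenyl on a saturated ring carbon. For the measured compounds named here, no measured pair shows directly what this change does on the shared core; the only guide is that the other variation measured so far, compound 2, gives the higher number. Compound 3 is thus expected to give a somewhat higher number than compound 1, a step of a 2.5-fold higher number from compound 1 to compound 3 (0.40 log units; beyond the scatter) that is expected to reach beyond the scatter. The estimate for compound 3 is 700 nM, with a range from 200 nM to 2500 nM.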

Compound 3, half-maximal effective concentration: 78 nM
Estimate against measurement, compound 3: 9.0-fold (0.95 log units) above; measured number below the stated range.
By their numbers in this assay, from the lowest: compound 3; then compound 1; then compound 2.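

In this assay, the saturated ring carbon three ring bonds from the ring nitrogen does not need 2-chloro-4-fluorophenyl for a low number: (2-fluorobenzyl)oxy in its place gives a 3.6-fold lower number from compound 1 to compound 3 (0.56 log units; beyond the scatter). The entering group keeps one six-membered aromatic ring of carbon only, loses the chlorine and adds an oxygen, counted as one hydrogen-bond acceptor, so several things change in this single step. Nothing measured here shows which of these differences accounts for the lower number.

Still open, from the compounds shown here alone, is whether the oxygen itself matters, which a benzylamino group, with nitrogen in place of that oxygen, could test. It is also unclear whether the fluorine is needed, as plain benzyloxy would show, or how a longer chain between the oxygen and the aromatic ring would fare.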